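This account rests on a few compounds, and the source may have more. Where it says the series, first, only, none or still open, it means among the compounds named here.

Three compounds built on one shared core have been run in a functional assay on MDA-MB-231 cells (Homo sapiens) for antiproliferative activity, read by CCK-8 assay, with a stated time of 72 h; on this read-out lower numbers stand for stronger inhibition and higher numbers for weaker inhibition. Compound 1 `O=C(Nc1cccc(-c2oc3cc(-c4ccc(F)cc4)ccc3c(=O)c2O)c1)c1ccccc1F` gives 7240 nM, compound 2 `Cc1ccc(C(=O)Nc2cccc(-c3oc4cc(-c5ccc(F)cc5)ccc4c(=O)c3O)c2)cc1` gives 4350 nM, and compound 3 `CCc1ccc(C(=O)Nc2cccc(-c3oc4cc(-c5ccc(F)cc5)ccc4c(=O)c3O)c2)cc1` gives 9070 nM. Compound 3 holds the highest number of the three, though its gap to compound 1 is within the scatter, whereas a 2.1-fold higher number from compound 2 to compound 3 (0.32 log units; beyond the scatter) is beyond it. Compound 4 `COc1cc(OC)cc(C(=O)Nc2cccc(-c3oc4cc(-c5ccc(F)cc5)ccc4c(=O)c3O)c2)c1` differs from compound 3 in a single place: 3,5-dimethoxyphenyl in place of 4-ethylphenyl on a carbonyl carbon. Among the measured compounds shown here, all the measured steps alter the same aryl group on the carbonyl carbon: a 1.7-fold lower number from compound 1 to compound 2 (0.22 log units; within the scatter) and a 1.3-fold higher number from compound 1 to compound 3 (0.10 log units; within the scatter). The step from compound 2 to compound 3 was noted above. None is large, so for compound 4 in this assay only a small step is expected, leaning toward a lower number, a 1.5-fold lower number from compound 3 to compound 4 (0.18 log units; within the scatter). Compound 4 is therefore estimated at 6000 nM, within 2500 nM to 15000 nM.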

Compound 4, half-maximal inhibitory concentration: 4040 nM
Beside the measured number, compound 4's estimate is 1.5-fold (0.17 log units) above it; the range from low to high includes it.
By their numbers in this assay, from the lowest: compounds 4, 2, 1 and 3 (each within the scatter of the next, the first and the last beyond it).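

In this assay, the change to 3,5-dimethoxyphenyl on the carbonyl carbon shows that this position accepts an aryl group bearing oxygen atoms with no loss against any earlier compound: a 2.2-fold lower number from compound 3 to compound 4 (0.35 log units; beyond the scatter) is beyond the scatter, whereas a 1.1-fold lower number from compound 2 to compound 4 (0.03 log units; within the scatter) and a 1.8-fold lower number from compound 1 to compound 4 (0.25 log units; within the scatter) both stay within it. Nothing available explains these differences. The compounds shown leave open how an amine or a carboxylic acid on this aryl ring, or a longer chain in its place, would read.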